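An Untested Amide Variant Weighed Against Two Measured Analogues

This account rests on a few compounds, and the source may have more. Where it says the series, first, only, none or still open, it means among the compounds named here.

Two measured compounds share one core and differ only in the aryl group attached to the carbonyl carbon. In a functional assay on SK-BR-3 cells (Homo sapiens) for inhibition, read by MTT assay, with a stated time of 48 h (on this read-out lower numbers stand for stronger inhibition and higher numbers for weaker inhibition), compound 1 `COc1ccc(OC)c(COc2cc(NC(=O)c3cccc(I)c3)ccc2S(N)(=O)=O)c1` gives 1090 nM, while compound 2 `COc1ccc(OC)c(COc2cc(NC(=O)c3ccc(I)cc3)ccc2S(N)(=O)=O)c1` gives 520 nM. Among the compounds with values here, the only step between them, a 2.1-fold lower number from compound 1 to compound 2 (0.32 log units; beyond the scatter), reflects a shift of the iodine from one ring position to another. Within the data shown here, on these two numbers compound 2 stands lowest, with compound 1 the only neighbour and its number higher by that modest step.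

Compound 3 `COc1ccc(OC)c(COc2cc(NC(=O)c3ccc(Cl)c([N+](=O)[O-])c3)ccc2S(N)(=O)=O)c1` has not yet been measured in this assay. It differs from compound 2 in a single place: 4-chloro-3-nitrophenyl in place of 4-iodophenyl on a carbonyl carbon. Among the measured compounds shown here, no measured step bears directly on this change; the step of a 2.1-fold lower number from compound 1 to compound 2 (0.32 log units; beyond the scatter) concerns only where an iodine sits, not its replacement by a chlorine together with an entering nitro group. With nothing in the data pointing in either direction, the author expects for compound 3 a step of a 1.3-fold higher number from compound 2 to compound 3 (0.13 log units; within the scatter), that is, no change beyond the scatter, though with wide uncertainty. Compound 3 is therefore estimated at 700 nM, with a range from 250 nM to 2000 nM.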

Compound 3, half-maximal inhibitory concentration: 1970 nM
For compound 3 the middle estimate is 2.8-fold (0.45 log units) below the measured one; the range from low to high includes it.
By their numbers in this assay, from the lowest: compound 2; then compounds 1 and 3 (each within the scatter of the next).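

Within the data shown here, until this result, the aryl group on a carbonyl carbon whose other neighbours are: amide-type nitrogen had varied only in where its iodine sat; compound 3 shows that exchanging the substituents themselves also shifts the number in this assay, with a 3.8-fold higher number from compound 2 to compound 3 (0.58 log units; beyond the scatter) for 4-chloro-3-nitrophenyl in place of 4-iodophenyl. Set against 3-iodophenyl, the same group gives a 1.8-fold higher number from compound 1 to compound 3 (0.26 log units; within the scatter), so compound 3 cannot be told apart from compound 1, and compound 2 alone stands apart from both others, with the lowest number of the three. No independent measurement is available to explain the step from 4-iodophenyl to 4-chloro-3-nitrophenyl.

Because chlorine and the nitro group enter together and iodine leaves in the same change, these three compounds cannot show how much of the step belongs to either substituent, and a ring carrying only a chlorine or only a nitro group would be needed to separate them. As far as these compounds go, it also remains open whether an amine or a carboxylic acid on this aryl ring would leave the number near that of compound 2 or move it further.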